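A few compounds are considered here, and "the series" means these few. Any claim that something is new, unique, unknown or untested is made for them only; others in the source may bear on it.

Measured so far:
compound 1 `NC(=O)[C@@H]1CC[C@H](c2ccc(Oc3ccc(F)cc3)cc2)N1` — 2 mL.min-1.g-1
compound 2 `N#Cc1cc([C@H]2CC[C@@H](C(N)=O)N2)ccc1OCc1ccccc1F` — 2 mL.min-1.g-1

Both values come from an ADME assay on microsomes from liver (Rattus norvegicus) for metabolic stability; a higher number here means faster removal of the compound, a lower number slower removal. Compound 2 stands level with compound 1 at the digits given; the pair lies within the usual scatter, so no order between them is claimed. Compound 3 `COc1cc([C@H]2CC[C@@H](C(N)=O)N2)ccc1OCc1ccccc1F` awaits measurement. It differs from compound 2 by methoxy in place of cyano on an aromatic carbon. Among the compounds with values here, the two measured compounds differ in more than one place, so they offer no single-change step to lean on. The step of a 2.0-fold higher number from compound 2 to compound 3 (0.30 log units; within the scatter) is expected to be modest, leaning toward faster removal. Compound 3 is estimated at 4 mL.min-1.g-1, range 1.5 mL.min-1.g-1 to 12 mL.min-1.g-1, in this assay.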

Compound 3, intrinsic clearance in microsomes: 4 mL.min-1.g-1
For compound 3 middle estimate and measured number coincide at the digits printed, within the range that was stated.
By their numbers in this assay, from the lowest: compounds 1, 2 and 3 (each within the scatter of the next).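

In this assay methoxy in place of cyano on an aromatic carbon gives a 2.0-fold higher number from compound 2 to compound 3 (0.30 log units; within the scatter) and so does not separate the two groups at this position. Within the data shown here, this is the first single-change reading, which compounds 1 and 2 could not give. Nothing available bears on why this step has its size. On these data alone, whether an amine, a carboxylic acid or a longer chain on this carbon would stay within the scatter of compound 2 remains open. Also open, as far as these compounds go, is whether the exchange reads alike with another group in place of the group of 9 heavy atoms.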